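This account rests on a few compounds, and the source may have more. Where it says the series, first, only, none or still open, it means among the compounds named here.

Measured compounds:
- compound 1 `C#Cc1cn([C@@H]2O[C@H](CO)[C@@H](O)[C@H]2O)c2ncnc(OC)c12`: 1730 nM
- compound 3 `C#Cc1cn([C@@H]2O[C@H](CO)[C@@H](O)[C@H]2O)c2ncnc(N(C)C)c12`: 810 nM
- compound 2 `O=c1[nH]cnc2c1c(-c1cccs1)cn2[C@@H]1O[C@H](CO)[C@@H](O)[C@H]1O`: a limit, > 20000 nM

In a functional assay on HeLa S3 cells (Homo sapiens) for antiproliferative activity, read by XTT assay, with a stated time of 72 h (a higher number here means a weaker inhibitor, a lower number a stronger inhibitor), compound 1 has the highest of the two numbers given; the nearest is compound 3, with a change of a 2.1-fold lower number from compound 1 to compound 3 (0.33 log units; beyond the scatter), a dimethylamino in place of methoxy on an aromatic carbon. Compound 2 stands only at the limit of > 20000 nM in this assay, at which 1 of the 3 values shown sits. Compound 4 `COc1ncnc2c1c(-c1ccoc1)cn2[C@@H]1O[C@H](CO)[C@@H](O)[C@H]1O` differs from compound 1 by furan-3-yl in place of ethynyl on an aromatic carbon. Within the data shown here, no measured step touches that position, so nothing directly bears on it; compound 2, which carries a ring at the same place on a different core, gives only a limit. A weaker result is therefore expected, but with wide uncertainty. The expected change is a 2.9-fold higher number from compound 1 to compound 4 (0.46 log units; beyond the scatter). Compound 4 is expected to give about 5000 nM, between 1500 nM and 20000 nM.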

Compound 4, half-maximal inhibitory concentration: 1790 nM
The estimate for compound 4 lay 2.8-fold (0.45 log units) above the measured number; the range from low to high includes it.
By their numbers in this assay, from the lowest: compound 3; then compounds 1 and 4 (each within the scatter of the next). At a limit, above all of these: compound 2.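

Replacing the two-carbon ethynyl with the aromatic furan-3-yl ring gives a 1.0-fold higher number from compound 1 to compound 4 (0.01 log units; within the scatter) in this assay and so shows that, with methoxy on the shared core, this aromatic carbon can carry a ring without leaving the scatter. Compound 2 could not show this, since it has a different core and gives only a limit. Nothing measured here explains why the two groups read alike. From the compounds shown here alone, it remains open whether an amine or a carboxylic acid at this carbon would match them, and whether furan-3-yl would read the same with dimethylamino in place of methoxy.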